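Replacing an Azetidine Nitrile with an Oxetanylmethoxy Nitrile

The source may hold more compounds than are shown below. What is called first, only, known or untested is meant among the compounds shown, and "the series" means these compounds.

Of the compounds shown here, three have been measured in a functional assay on cells for antagonist activity at Free fatty acid receptor 1 (Homo sapiens), read by TR-FRET and inositol phosphate accumulation, with a stated time of 2 h; on this read-out higher numbers stand for weaker inhibition and lower numbers for stronger inhibition. Within the data shown here, compound 1 `COc1cccc(OCc2cc(C)nc(-c3ccccn3)n2)c1` gives 2000 nM, and compound 2 `Cc1cc(COc2cccc(F)c2)nc(-c2ccccn2)n1` gives 794 nM, the single one-place step being a 2.5-fold lower number from compound 1 to compound 2 (0.40 log units; beyond the scatter). Compound 3 `CC1(C#N)CN(c2cc(COc3ccc(F)c(F)c3F)nc(-c3ccccn3)n2)C1` gives 158 nM in this assay , the lowest of the three numbers; its gap to compound 2 and to compound 1 is in each case beyond the scatter.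

Compound 4 `N#CCC1(COc2cc(COc3ccc(F)c(F)c3F)nc(-c3ccccn3)n2)COC1` differs from compound 3 in one place: (3-(cyanomethyl)oxetan-3-yl)methoxy in place of 3-cyano-3-methylazetidin-1-yl on an aromatic carbon. Among the measured compounds shown here, no measured step bears on this exchange. For the measured compounds named here, the only one-place step seen so far, from compound 1 to compound 2, concerns a different group on a different ring, and compound 3 differs from compound 2 in more than one place, so only the two values themselves can be compared. The change keeps a four-membered ring bearing a nitrile but alters the linking atom and lengthens the tether. With nothing to anchor it, compound 4 is expected to land somewhat weaker than compound 3, by a step of a 2.0-fold higher number from compound 3 to compound 4 (0.31 log units; beyond the scatter), with wide uncertainty. On that basis compound 4 is estimated at 320 nM in this assay , within a range from 80 nM to 1300 nM.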

Compound 4, half-maximal inhibitory concentration: 398 nM
For compound 4 the middle estimate is 1.2-fold (0.09 log units) below the measured one, and the stated range covers the measured number.
By their numbers in this assay, from the lowest: compound 3; then compounds 4 and 2 (each within the scatter of the next); then compound 1.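

In this assay, the exchange at this aromatic carbon, opposite the ring nitrogen, gives a 2.5-fold higher number from compound 3 to compound 4 (0.40 log units; beyond the scatter), the only step shown at this position, so the size of the effect here now has a first measure. Compound 4 still reads 398 nM with the larger (3-(cyanomethyl)oxetan-3-yl)methoxy group in place, which carries one more hydrogen-bond acceptor than the 3-cyano-3-methylazetidin-1-yl group it replaces, so this position holds a group of either kind with only a modest shift in the number. The exchange alters the hetero atom of the four-membered ring, the link to the core and the placement of the nitrile all at once, and nothing available explains the shift or assigns it to any one of these parts.

Still open, as far as these compounds go, is which of these parts carries the step, a question that a (3-(cyanomethyl)azetidin-3-yl)methoxy group, keeping the oxygen link but with a nitrogen in the ring, could help to separate. Also open, from the compounds shown here alone, is what the four-membered ring adds at all, which a morpholine or a plain methoxy group at the same carbon would address.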